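Replacing a Phenoxy Group in a Thromboxane Synthase Inhibitor

The source may hold more compounds than are shown below. What is called first, only, known or untested is meant among the compounds shown, and "the series" means these compounds.

Compound 1 `O=C(O)CC/C=C\CC1COC(c2ccco2)OC1c1cccnc1` and compound 2 `Cc1ccc(OC(C)(C)C2OCC(C/C=C\CCC(=O)O)C(c3cccnc3)O2)cc1` share a core built around a saturated ring that carries a pyridine and a chain ending in a carboxylic acid. In an assay for inhibition of Thromboxane-A synthase (Homo sapiens), using microsomes (a higher number here means a weaker inhibitor, a lower number a stronger inhibitor), compound 1 gives 164 nM. In this assay compound 2 gives 360 nM, the higher of the two numbers; the gap to compound 1 lies beyond the usual scatter, so compound 2 is the weaker inhibitor of the pair.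

Compound 3 `Cc1ccc(SC(C)(C)C2OCC(C/C=C\CCC(=O)O)C(c3cccnc3)O2)c([N+](=O)[O-])c1` is not yet measured. It differs from compound 2 in one place: a group of 11 heavy atoms (7 carbon, 1 nitrogen, 2 oxygen, 1 sulfur; one six-membered aromatic ring of carbon only) in place of a group of 8 heavy atoms (7 carbon, 1 oxygen; one six-membered aromatic ring of carbon only), on a saturated chain carbon bound to two saturated chain carbons and a saturated ring carbon. The group that enters keeps the six-membered aromatic ring of carbon only but carries 1 sulfur and 3 hydrogen-bond acceptors.

Among the compounds with values here, no measured pair in this set shows what such a swap does, so no step beyond the scatter is expected; the step from compound 2 to compound 3 is estimated at a 1.1-fold lower number from compound 2 to compound 3 (0.05 log units; within the scatter). Compound 3 is therefore expected to give 320 nM in this assay, within a range of 100 nM to 1000 nM.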

Compound 3, half-maximal inhibitory concentration: 30 nM
Compound 3: middle estimate off by 11-fold (1.03 log units), on the high side; the whole stated range lies above it.
By their numbers in this assay, from the lowest: compound 3; then compound 1; then compound 2.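

The group on this saturated chain carbon bound to two saturated chain carbons and a saturated ring carbon strongly affects the result: in this assay, replacing 4-methylphenoxy with the larger sulfur- and nitrogen-bearing group gives a 12-fold lower number from compound 2 to compound 3 (1.08 log units; beyond the scatter). Within the data shown here, compounds 1 and 2 could not show this, as they offered no step between compounds that differ in one place, and this is the first sign that inhibition responds to a change at this position. Nothing measured here accounts for the size of this step.

Whether the step comes from the sulfur, the added nitro group or the two together stays open, as no compound shown carries only one of them. The compounds shown also leave open how an amine in place of the nitro group would fare.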